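Purine series: 4-hydroxyphenyl in place of 3,4-dichlorophenyl

A few compounds are considered here, and "the series" means these few. Any claim that something is new, unique, unknown or untested is made for them only; others in the source may bear on it.

Compound 1 `CN1CCN(c2nc(-c3ccc(Cl)c(Cl)c3)nc3[nH]cnc23)CC1` gives 631 nM in an assay on cells for displacement of a labelled ligand from adenosine receptor A1 (Homo sapiens), read by scintillation counting and radioligand binding, with a stated time of 60 min (on this read-out lower numbers stand for stronger inhibition and higher numbers for weaker inhibition), the higher of the two numbers recorded so far. Compound 2 `Clc1ccc(-c2nc(N3CCCCC3)c3nc[nH]c3n2)cc1` gives 126 nM in this assay, and compound 1 stands beyond the scatter above it. Compound 3 `CN1CCN(c2nc(-c3ccc(O)cc3)nc3[nH]cnc23)CC1` has not been measured; it differs from compound 1 in one place: 4-hydroxyphenyl in place of 3,4-dichlorophenyl on an aromatic carbon. Among the compounds with values here, no measured pair isolates this change, so its direction is open. The expected step of a 1.6-fold higher number from compound 1 to compound 3 (0.20 log units; within the scatter) is small, a modest weakening or nothing beyond the scatter. For compound 3 the estimate in this assay is 1000 nM, within a range from 300 nM to 4000 nM.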

Compound 3, inhibition constant: 398 nM
The estimate for compound 3 lay 2.5-fold (0.40 log units) above the measured number; the range from low to high includes it.
By their numbers in this assay, from the lowest: compound 2; then compounds 3 and 1 (each within the scatter of the next).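

Exchanging 3,4-dichlorophenyl for 4-hydroxyphenyl on the aromatic carbon between two ring nitrogen atoms gives a 1.6-fold lower number from compound 1 to compound 3 (0.20 log units; within the scatter) in this assay. With the 4-methylpiperazin-1-yl group in place, this position therefore accepts a phenyl ring without chlorine and with a hydroxyl, with no change beyond the scatter. Nothing available explains why the step is this small.

Going by these compounds, it remains open whether a 4-aminophenyl or a 4-carboxyphenyl group would behave the same way at this position. On these data alone, the effect of the same exchange alongside the other group on compound 2 also remains open.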